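The source may hold more compounds than are shown below. What is called first, only, known or untested is meant among the compounds shown, and "the series" means these compounds.

Compound 1 `CNc1nc(SC)nc2c1ncn2[C@@H]1C[C@@H](O)[C@H](CO)O1` gives > 300 uM in a functional assay on HL-60 cells (Homo sapiens); on this read-out lower numbers stand for stronger inhibition and higher numbers for weaker inhibition.
Compound 2 `Nc1nc(Br)nc2c1ncn2[C@@H]1C[C@@H](O)[C@H](CO)O1` gives 41 uM in this assay.

In this assay the value of compound 1 is a limit of the assay, not a number. Within the data shown here, compound 2 therefore holds the only number in this assay, the other value sitting at the limit of > 300 uM in this assay, at which 1 of the 2 values shown sits. Compound 3 `CNc1nc(Br)nc2c1ncn2[C@@H]1C[C@@H](O)[C@H](CO)O1` differs from compound 2 by methyl in place of hydrogen on a nitrogen on an aromatic ring. Among the measured compounds shown here, no measured pair isolates this change, since compound 1 differs from compound 2 in a second place as well. Compound 3 is expected to come out weaker than compound 2 by a 2.4-fold higher number from compound 2 to compound 3 (0.39 log units; beyond the scatter), a step beyond the scatter. Compound 3 is estimated at 100 uM, within 30 uM to 300 uM.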

Compound 3, concentration for 50% inhibition: 143 uM
Compound 3: the middle estimate sits 1.4-fold (0.16 log units) below what was measured; measured number inside the range.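

Read with the bromo group held fixed, methyl in place of hydrogen on the nitrogen on the aromatic ring gives a clean reading in this assay: the amino to methylamino change produces a 3.5-fold higher number from compound 2 to compound 3 (0.54 log units; beyond the scatter). With the methylamino group held fixed, bromo in place of methylsulfanyl on an aromatic carbon gives an at least 2.0-fold lower number from compound 1 to compound 3 (0.32 log units; beyond the scatter), so the group on that carbon also matters. This second step gives only a bound, since the value of compound 1 is a limit of the assay: the limit of > 300 uM in this assay, at which 1 of the 3 values shown sits.

Going by these compounds, it remains open how an ethyl group on that nitrogen would read. On these data alone, it is also open whether chloro or an amine in place of bromo would keep the number of compound 2.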